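This account rests on a few compounds, and the source may have more. Where it says the series, first, only, none or still open, it means among the compounds named here.

Measured in an ADME assay on A549 cells (Homo sapiens) for cytotoxicity, read by resazurin assay, with a stated time of 48 h; on this read-out higher numbers stand for lower toxicity in this test and lower numbers for higher toxicity in this test:
- compound 1 `O=C(Nc1ccc(NCc2cccc(C(F)(F)F)c2)cc1Cl)c1cc(Cl)ccc1O`: 13300 nM
- compound 2 `O=C(Nc1ccc(NCc2cc(F)cc(Cl)c2)cc1Cl)c1cc(Cl)ccc1O`: 11100 nM

Within the data shown here, compound 2 stands level with compound 1, its only neighbour: the sole measured step is a 1.2-fold lower number from compound 1 to compound 2 (0.08 log units; within the scatter). Compound 3 `O=C(Nc1ccc(NCc2cnccc2Cl)cc1Cl)c1cc(Cl)ccc1O` carries 4-chloropyridin-3-yl in place of 3-chloro-5-fluorophenyl on a saturated chain carbon bound to a nitrogen on an aromatic ring. Among the measured compounds shown here, no measured compound has a ring with a hetero atom at this place, so the only guide is a 1.2-fold lower number from compound 1 to compound 2 (0.08 log units; within the scatter), and no shift beyond the scatter is expected in this assay. The expected step is a 1.3-fold higher number from compound 2 to compound 3 (0.10 log units; within the scatter). For compound 3 the estimated value is 14000 nM, with an expected range of 6000 nM to 32000 nM.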

Compound 3, half-maximal cytotoxic concentration: 126000 nM
Compound 3: middle estimate off by 9.0-fold (0.95 log units), on the low side, outside the stated range (above it).
By their numbers in this assay, from the lowest: compounds 2 and 1 (each within the scatter of the next); then compound 3.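

At this place, on a saturated chain carbon bound to a nitrogen on an aromatic ring, the read-out in this assay is not flat: 4-chloropyridin-3-yl gives an 11-fold higher number from compound 2 to compound 3 (1.06 log units; beyond the scatter) and a 9.5-fold higher number from compound 1 to compound 3 (0.98 log units; beyond the scatter) on the side of lower toxicity in this test. Among these compounds, the two carbon-only rings gave no such separation, so the ring with 1 hetero atom is the first change here to move the number beyond the scatter. Nothing measured explains the shift.

From the compounds shown here alone, whether the ring nitrogen alone carries the step, with the fluorine unchanged, remains open. Also open, going by these compounds, is how a pyridine without chlorine, or a ring bearing an amine or a carboxylic acid, would read.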